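A few compounds are considered here, and "the series" means these few. Any claim that something is new, unique, unknown or untested is made for them only; others in the source may bear on it.

Measured so far:
- compound 1 `CCCn1c(=O)[nH]c2nc(-c3ccc(S(=O)(=O)N4CCN(c5ccc(Cl)cc5F)CC4)cc3)[nH]c2c1=O`; in an assay on CHO cells for displacement of a labelled ligand from adenosine receptor A1 (Homo sapiens), read by scintillation counting, with a stated time of 90 min, in the presence of a further agent that is not named here (a lower number here means a stronger inhibitor, a higher number a weaker inhibitor), compound 1 gives > 1000 nM, a limit of the assay, not a number.
- compound 2 `CCCn1c(=O)[nH]c2nc(-c3ccc(S(=O)(=O)N4CCN(c5cccc(F)c5)CC4)cc3)[nH]c2c1=O`; in this assay compound 2 gives > 1000 nM, likewise a limit.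

Compound 1 therefore stands only at the limit; the step that the two limits leave unreadable from compound 1 to compound 2 cannot be read because of the limit of > 1000 nM in this assay, at which 2 of the 2 values shown sit.

Compound 3 `CCCn1c(=O)[nH]c2nc(-c3ccc(S(=O)(=O)N4CCN(c5ccccc5)CC4)cc3)[nH]c2c1=O` differs from compound 1 by phenyl in place of 4-chloro-2-fluorophenyl on an amine nitrogen in a ring. Among the compounds with values here, the only measured step that bears on this place is the unreadable one from compound 1 to compound 2, so no shift beyond the scatter is expected in this assay, and the estimate is a step that the limit leaves unreadable from compound 1 to compound 3. Compound 3 is estimated at 2000 nM, within 700 nM to 10000 nM, most likely again reported only as a limit.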

Compound 3, inhibition constant: 364 nM
Compound 3: middle estimate off by 5.5-fold (0.74 log units), on the high side; the whole stated range lies above it.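

In this assay, hydrogen in place of fluoro on the aromatic carbon gives an at least 2.7-fold lower number from compound 2 to compound 3 (0.43 log units; beyond the scatter), and phenyl in place of 4-chloro-2-fluorophenyl gives an at least 2.7-fold lower number from compound 1 to compound 3 (0.43 log units; beyond the scatter). The substituent on the phenyl at this ring amine nitrogen therefore does register, which the unreadable step between compound 1 and compound 2 could not show. Both sizes are minimum sizes because only limits stand for compound 1 and compound 2: the limit of > 1000 nM in this assay, at which 2 of the 3 values shown sit.

Going by these compounds, the order of compound 1 and compound 2 stays open. So does the effect of a methoxy group on this phenyl, or of a benzyl group in its place.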